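This account rests on a few compounds, and the source may have more. Where it says the series, first, only, none or still open, it means among the compounds named here.

In a functional assay on HepG2 cells (Homo sapiens) for antiproliferative activity, read by sulforhodamine B assay, with a stated time of 3 days (a higher number here means that more compound is needed for the effect, a lower number that less compound is needed), compound 1 (`CCCC1=C(OCC(C)C)C(CCC)(CCC)C(=O)/C(=C(O)\C=C\c2ccccc2)C1=O`) gives 13.4 uM and compound 2 (`CCCCOC1=C(CCC)C(=O)/C(=C(O)/C=C/c2ccccc2)C(=O)C1(CCC)CCC`) gives 8 uM. These two values, the only ones measured so far, lie within the scatter of each other, so compound 2 does not stand apart from compound 1. Compound 3 (`CCCC1=C(OCC)C(CCC)(CCC)C(=O)/C(=C(O)\C=C\c2ccccc2)C1=O`) differs from compound 2 by one change: hydrogen in place of ethyl on a saturated chain carbon, two bonds along the chain from an oxygen on an unsaturated carbon. This places hydrogen in place of ethyl on a saturated chain carbon, two bonds along the chain from an oxygen on an unsaturated carbon, and so reads as butoxy to ethoxy. Going by the values given here, the one measured step that bears on it, propyl in place of isopropyl in the chain on that oxygen, is a 1.7-fold lower number from compound 1 to compound 2 (0.22 log units; within the scatter), within the scatter. That step does not shorten the chain, so its support is indirect. No step beyond the scatter is therefore expected in this assay. The expected value for compound 3 is 10 uM, with an estimated range of 5 uM to 20 uM. The estimated step is a 1.3-fold higher number from compound 2 to compound 3 (0.10 log units; within the scatter).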

Compound 3, concentration for half-maximal effect: 11.2 uM
For compound 3 the middle estimate is 1.1-fold (0.05 log units) below the measured one, and the stated range covers the measured number.
By their numbers in this assay, from the lowest: compounds 2, 3 and 1 (each within the scatter of the next).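

In this assay, butoxy to ethoxy, a true shortening of the chain on this oxygen, gives a 1.4-fold higher number from compound 2 to compound 3 (0.15 log units; within the scatter), so removing the ethyl at this place does not move the number beyond the scatter. Methyl in place of isopropyl on the saturated chain carbon bound to that oxygen gives a 1.2-fold lower number from compound 1 to compound 3 (0.08 log units; within the scatter), so the ethoxy chain and the branched chain also remain within the scatter, and the three chains shown are not separated by this assay. Nothing available bears on why these chains read alike.

The compounds shown leave open whether a longer chain such as hexyloxy, or an amine or a carboxylic acid at the end of the chain, would give a step beyond the scatter. They also leave open whether changes elsewhere on the shared core would do so.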